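The source may report more compounds than this note shows. Statements on the series, on what has been measured and on what is new or still open speak of the compounds shown alone.

In an assay on CHO cells for displacement of a labelled ligand from adenosine receptor A1 (Homo sapiens), read by scintillation counting (a lower number here means a stronger inhibitor, a higher number a weaker inhibitor), compound 1 `Nc1nc(Cc2ccccc2Cl)nc2cn(-c3ccccc3)nc12` gives 155 nM. Compound 2 `Nc1nc(CCc2ccc(O)cc2)nc2cn(-c3ccccc3)nc12`, whose chain carries a different aromatic group, gives 420 nM in this assay. Within the data shown here, the only measured step, a 2.7-fold higher number from compound 1 to compound 2 (0.43 log units; beyond the scatter), is therefore the whole of what is known, and compound 2 stands as the higher of the two numbers, with compound 1 the nearest and only neighbour.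

Compound 3 `Nc1nc(CCCc2ccccc2)nc2cn(-c3ccccc3)nc12` has not yet been measured in this assay. It differs from compound 2 as follows: benzyl in place of 4-hydroxyphenyl on a saturated chain carbon, two bonds along the chain from an aromatic carbon. Among the measured compounds shown here, the one measured step bears on this only loosely, since it swapped one aromatic group for another while also lengthening the chain, whereas here the hydroxyl leaves and the chain grows by one link. That step was modest in size, and compound 1, which also lacks the hydroxyl, gave the lower number of the pair. For compound 3 a number near the two measured values, perhaps somewhat lower than that of compound 2, is expected, as a 1.4-fold lower number from compound 2 to compound 3 (0.15 log units; within the scatter). The estimate for compound 3 in this assay is 300 nM, with a range from 90 nM to 1000 nM.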

Compound 3, inhibition constant: 5.31 nM
Compound 3: the middle estimate sits 56-fold (1.75 log units) above what was measured; measured number outside the range, below it.
By their numbers in this assay, from the lowest: compound 3; then compound 1; then compound 2.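

In this assay, among these compounds, benzyl in place of 4-hydroxyphenyl at this place on the chain, which can also be read as phenethyl in place of 4-hydroxybenzyl, gives a 79-fold lower number from compound 2 to compound 3 (1.90 log units; beyond the scatter) and so shows that this end of the molecule can move the number far more than the one earlier step suggested. The comparison with the other neighbour points the same way: phenethyl in place of 2-chlorophenyl on a saturated chain carbon bound to an aromatic carbon gives a 29-fold lower number from compound 1 to compound 3 (1.47 log units; beyond the scatter), which makes compound 3 the strongest inhibitor of the three, with both of its steps beyond the scatter. Nothing at hand explains why the number falls so steeply with this change.

The step from compound 2 to compound 3 removes the hydroxyl and lengthens the chain by one link at once, so these compounds leave open how much of the drop belongs to each of the two changes. Also open, going by these compounds, is what a still longer chain, or a methoxy group or an amine on the aromatic ring of compound 3, would do to the number.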